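This account rests on a few compounds, and the source may have more. Where it says the series, first, only, none or still open, it means among the compounds named here.

Among the compounds with values here, in a functional assay on SK-MEL-2 cells (Homo sapiens) for cytotoxicity (a higher number here means a weaker inhibitor, a lower number a stronger inhibitor), compound 1 (`O=C1NC(c2ccc(Cl)cc2)CN1S(=O)(=O)c1ccc2c(c1)CCC2`) gives 64300 nM, the lowest number of the three compounds measured so far. Compound 2 (`Cc1ccc(C2CNC(=O)N2S(=O)(=O)c2ccccc2)cc1`) gives 144000 nM, and compound 3 (`Cc1ccc(C2CNC(=O)N2S(=O)(=O)c2ccc(C)cc2)cc1`) gives 234000 nM. Compound 4 (`Cc1ccc(C2CN(S(=O)(=O)c3ccc4c(c3)CCC4)C(=O)N2)cc1`) has not yet been measured. It keeps the structure of compound 1 except that 4-chlorophenyl becomes 4-methylphenyl, with methyl in place of chloro on an aromatic carbon.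

Within the data shown here, no measured pair makes this exact change. The closest evidence is a 1.6-fold higher number from compound 2 to compound 3 (0.21 log units; within the scatter), a step that puts methyl in place of hydrogen at a different place in the molecule and stays within the scatter. It suggests that adding a methyl need not move the number much, but it says nothing direct about losing a chloro. Compound 2 and compound 3 both carry the 4-methylphenyl group and both show higher numbers than compound 1, yet they also differ from it elsewhere, so this is only a weak hint.

A small shift toward a higher number is therefore expected, and the estimated change is a 1.5-fold higher number from compound 1 to compound 4 (0.17 log units; within the scatter). For compound 4, the expected value is 95000 nM, with an estimated range from 45000 nM to 200000 nM.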

Compound 4, half-maximal inhibitory concentration: 72500 nM
The estimate for compound 4 lay 1.3-fold (0.12 log units) above the measured number; measured number inside the range.
By their numbers in this assay, from the lowest: compounds 1, 4, 2 and 3 (each within the scatter of the next, the first and the last beyond it).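

Within this assay, the exchange of 4-chlorophenyl for 4-methylphenyl on the core of compound 1 gives a 1.1-fold higher number from compound 1 to compound 4 (0.05 log units; within the scatter), so the two numbers cannot be told apart. Within the data shown here, this is the first direct reading at this place, on an aromatic carbon para to a large group, and it shows that chloro and methyl read alike here, at least on this core. Among these compounds, the earlier methyl step, a 1.6-fold higher number from compound 2 to compound 3 (0.21 log units; within the scatter), sits at a different place in the molecule and also stays within the scatter, but only this new step speaks to the loss of the chloro; no data here offer a reason why the two groups read alike.

With only chloro and methyl shown at this place, it remains open whether a very different group there, such as an amine, a carboxylic acid or a longer chain, would leave the number just as it is. On these data alone, it is equally open whether the same exchange would read alike on the core of compound 2, since one pair on one core cannot establish a general pattern.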